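Swapping the thioether substituent on a shared iodinated core

The compounds below may be only part of what the source reports. "The series", "measured", "known", "first", "only" and "open" are said of these compounds alone.

Measured so far:
Compound 1, `CC(=O)c1ccc(CSc2nc(Cc3cc(C)cc(C)c3)c(I)c(=O)[nH]2)cc1`: 78300 nM
Compound 2, `Cc1cc(C)cc(Cc2nc(SCCOc3ccc([N+](=O)[O-])cc3)[nH]c(=O)c2I)c1`: 96600 nM

Of the compounds shown here, two built on one core have been tested in an ADME assay on HepG2 2.2.15 cells (Homo sapiens) for cytotoxicity, read by MTT assay, with a stated time of 72 h; on this read-out higher numbers stand for lower toxicity in this test and lower numbers for higher toxicity in this test. Compound 1 gives 78300 nM, and compound 2 gives 96600 nM. These two numbers lie within the usual scatter of each other, so compound 1 is not set apart from compound 2 on this read-out.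

The next compound, compound 3 `Cc1cc(C)cc(Cc2nc(SCCOc3ccccc3)[nH]c(=O)c2I)c1`, has not yet been measured in this assay. It is related to compound 1 by one change: phenoxymethyl in place of 4-acetylphenyl on a saturated chain carbon bound to a sulfur. Among the measured compounds shown here, no measured pair shows a step of this kind, so the expectation rests only on the two values at hand, which sit close together.

Compound 3 is therefore expected to give a number near those of its neighbours, with an estimated step of a 1.1-fold higher number from compound 1 to compound 3 (0.06 log units; within the scatter) that stays within the scatter. The estimate for compound 3 in this assay is 90000 nM, with a range from 45000 nM to 180000 nM.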

Compound 3, half-maximal cytotoxic concentration: > 100000 nM
Compound 3: only a limit was reported (the forecaster's own chance of this, stated with the estimate: 15%); middle value at least 1.1-fold (0.04 log units) from the limit.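

In this assay compound 3 gives no number, only a limit: the limit of > 100000 nM in this assay, at which 1 of the 3 values shown sits.

Read against that limit, phenoxymethyl in place of 4-acetylphenyl on a saturated chain carbon bound to a sulfur gives an at least 1.2-fold higher number from compound 1 to compound 3 (0.10 log units; that floor lies within the scatter), and hydrogen in place of nitro on an aromatic carbon gives an at least 1.0-fold higher number from compound 2 to compound 3 (0.01 log units; that floor lies within the scatter). Neither change is thus shown to raise toxicity in this test, though the true size of either step cannot be read.

Going by these compounds, the real position of compound 3 beyond its limit remains open. Also open, on these data alone, is whether an amine or a carboxylic acid in place of nitro on that aromatic carbon, or a longer chain on the sulfur, would give a number clearly apart from these.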